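The source may hold more compounds than are shown below. What is called first, only, known or untested is meant among the compounds shown, and "the series" means these compounds.

Compound 1 `CCN(CC)CCCOc1cc2ncnc(Nc3ccc(C#N)cc3)c2cc1OC`: > 100000 nM, a limit.
Compound 2 `COc1cc2c(Nc3ccc(C#N)cc3)ncnc2cc1OCCCN(C)Cc1ccccc1`: > 100000 nM, a limit.
Compound 3 `CCOC(=O)C1CCN(CCCOc2cc3ncnc(Nc4ccc(C#N)cc4)c3cc2OC)CC1`: 34900 nM.

Among the compounds with values here, in a functional assay on MCF7 cells (Homo sapiens) for antiproliferative activity, read by MTT assay, with a stated time of 72 h (a lower number here means a stronger inhibitor, a higher number a weaker inhibitor), compound 3 gives 34900 nM, the only actual number. Compound 1 and compound 2 give only (the limit of > 100000 nM in this assay, at which 2 of the 3 values shown sit).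

Compound 4 `COc1cc2c(Nc3ccc(C#N)cc3)ncnc2cc1OCCCN1CCC(N(C)C)CC1` has dimethylamino in place of ethoxycarbonyl on a saturated ring carbon, three ring bonds from the ring nitrogen: dimethylamino in place of ethoxycarbonyl on a saturated ring carbon.

Within the data shown here, no measured step changes this group alone. The nearest evidence is an at least 2.8-fold lower number from compound 1 to compound 3 (0.45 log units; beyond the scatter) and an at least 2.8-fold lower number from compound 2 to compound 3 (0.45 log units; beyond the scatter), and each has a limit at one end, so each gives a bound and not a full size. The step that the two limits leave unreadable from compound 1 to compound 2 adds no size. Among the measured compounds shown here, compound 3 is the only compound with ethoxycarbonyl and the only one with a number, so losing that group is expected to move this assay towards a higher number, by a modest amount, and a result at the limit remains possible.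

The expected change is a 1.4-fold higher number from compound 3 to compound 4 (0.16 log units; within the scatter).

For compound 4 the estimated value is 50000 nM, with an expected range of 15000 nM to 100000 nM.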

Compound 4, half-maximal inhibitory concentration: 31000 nM
Compound 4: middle estimate off by 1.6-fold (0.21 log units), on the high side, and the stated range covers the measured number.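

In this assay, within the data shown here, the first direct reading at this saturated ring carbon, three ring bonds from the ring nitrogen, is a 1.1-fold lower number from compound 3 to compound 4 (0.05 log units; within the scatter), so dimethylamino in place of ethoxycarbonyl leaves the value within the scatter, and a measurable number does not depend on ethoxycarbonyl. The 4-(dimethylamino)piperidin-1-yl side chain also separates from the two open-chain amines, with an at least 3.2-fold lower number from compound 2 to compound 4 (0.50 log units; beyond the scatter) and an at least 3.2-fold lower number from compound 1 to compound 4 (0.50 log units; beyond the scatter), so among these four compounds the two 4-substituted piperidin-1-yl compounds give numbers and compound 1 and compound 2 do not. Both of those steps start from a limit and give only bounds: the limit of > 100000 nM in this assay, at which 2 of the 4 values shown sit.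

The compounds shown leave open whether the ring carbon needs any group at all, as a plain piperidin-1-yl would test. Going by these compounds, a carboxylic acid or a hydroxyl at that carbon, or a longer chain to the ring nitrogen, also remains open.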